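Moving from a propoxybenzyl to a difluoromethoxyphenylethyl group

The source may report more compounds than this note shows. Statements on the series, on what has been measured and on what is new or still open speak of the compounds shown alone.

Measured compounds:
compound 1 `Cc1ccc2cc(CN(Cc3ccc(Cl)cc3)Cc3ccc(C(C)C)cc3)c(=O)[nH]c2c1` — > 33000 nM
compound 2 `Cc1ccc2cc(CN(Cc3ccc(C(C)(C)C)cc3)Cc3cc(F)cc(F)c3)c(=O)[nH]c2c1` — > 33000 nM
compound 3 `CCCOc1ccc(CN(Cc2ccc(C(C)(C)C)cc2)Cc2cc3cc(C)ccc3[nH]c2=O)cc1` — > 5000 nM

The three measured compounds were tested in a toxicity assay on MDCK cells (Canis lupus familiaris) for cytotoxicity, read by crystal violet staining, with a stated time of 48 h; on this read-out higher numbers stand for lower toxicity in this test and lower numbers for higher toxicity in this test. For compound 1 the result is a limit of the test, > 33000 nM. For compound 2 the result is likewise a limit, > 33000 nM. For compound 3 the result is a limit as well, > 5000 nM, so compound 3 stands among values that are all limits rather than numbers: two of them sit at the limit of > 33000 nM in this assay, at which 2 of the 3 values shown sit, and compound 3 sits at the limit of > 5000 nM in this assay, at which 1 of the 3 values shown sits.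

Compound 4 `Cc1ccc2[nH]c(=O)c(CN(Cc3ccc(C(C)(C)C)cc3)C(C)c3ccc(OC(F)F)cc3)cc2c1` differs from compound 3 in one place: 1-(4-(difluoromethoxy)phenyl)ethyl in place of 4-propoxybenzyl on an amine nitrogen. Within the data shown here, no step between measured compounds is known for this change. Compound 4 is expected to remain weakly cytotoxic in this assay, so that a step that the limit leaves unreadable from compound 3 to compound 4 is estimated to be no more than the usual scatter and could again be a limit. For compound 4 the estimate is 25000 nM, within 8000 nM to 60000 nM.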

Compound 4, half-maximal cytotoxic concentration: > 5000 nM
Compound 4: a limit, no number; the forecaster's own chance of this, stated with the estimate: 65%; the middle value is on the limit's open side.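

Among these compounds, compound 3 and compound 4 both give limits rather than numbers in this assay, so no step between them can be read. The compounds shown leave open how cytotoxic either one actually is, and whether 1-(4-(difluoromethoxy)phenyl)ethyl in place of 4-propoxybenzyl changes that at all.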